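Removing One Fluoro: What to Expect of Compound 4

The source may hold more compounds than are shown below. What is called first, only, known or untested is meant among the compounds shown, and "the series" means these compounds.

Of the compounds shown here, three built on the same core have been tested in a functional assay on the whole organism with Mus musculus as the target, at a dose of 100 mg/kg by the intraperitoneal route; a higher number here means more inhibition at the dose given (going by the name of the read-out), a lower number less inhibition. Compound 1, `CN(C)C(=O)/C=C1\CCc2ccc(F)cc21`, gives in this assay an inhibition of 100%. Compound 2, `CN(C)C(=O)/C=C1\CCc2c(F)cc(F)cc21`, gives in this assay 100%. Compound 3, `O=C(/C=C1\CCc2c(F)cc(F)cc21)NC1CC1`, gives in this assay 100%.

Two single changes link them. From compound 2 to compound 1 the change is hydrogen in place of fluoro on an aromatic carbon, and the step in this assay is no change at the digits printed from compound 2 to compound 1 (within the scatter). From compound 2 to compound 3 the change is cyclopropylamino in place of dimethylamino on a carbonyl carbon, and the step is no change at the digits printed from compound 2 to compound 3 (within the scatter). Compound 3 thus stands level with compound 1 and compound 2 at the digits reported.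

Compound 4, `O=C(/C=C1\CCc2c(F)cccc21)NC1CC1`, has not yet been measured. It differs from compound 3 by hydrogen in place of fluoro on an aromatic carbon. Going by the values given here, this is the same kind of change as the one from compound 2 to compound 1, though not the same change: in compound 2 the aromatic carbon that loses its fluoro is ortho to a fused ring, meta to a fluoro group and meta to a fused ring, whereas in compound 3 it is meta to a fluoro group, meta to a fused ring and para to a fused ring. The two cores differ by cyclopropylamino in place of dimethylamino on a carbonyl carbon.

The step in this assay is expected to be a number 2 percentage points lower from compound 3 to compound 4 (within the scatter), because compound 3 sits at 100% and because the earlier removal of a fluoro gave no change at the digits printed from compound 2 to compound 1 (within the scatter). Compound 4 is therefore estimated to give 98% in this assay, within a range from 85% to 100%. Whether that expectation holds awaits the measurement.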

Compound 4, a percentage reported as inhibition, in the whole organism at one dose (the size of the read-out at that dose, not a potency): 100%
For compound 4 the middle estimate is 2 percentage points below the measured one; the range from low to high includes it.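

In this assay, hydrogen in place of fluoro on an aromatic carbon gives no change at the digits printed from compound 3 to compound 4 (within the scatter). Set beside the earlier case, the change carries across the dimethylamino and cyclopropylamino cores in this read-out, even though the carbon that loses its fluoro is not the same one in the two cores: the same change on two cores in this assay, no change at the digits printed (within the scatter) from compound 2 to compound 1 and no change at the digits printed (within the scatter) from compound 3 to compound 4, 0 percentage points apart, within the scatter of two such steps. Going by these compounds alone, this agreement rests on only two pairs, however, and all four compounds print the same value, so it gives no rule for the series; since the read-out is the size of the effect at a single dose and not a potency, it also cannot show whether compounds with the same value would still match at another dose, or whether the fluoro matters under such conditions.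

The compounds shown carry only fluoro or hydrogen at the varied aromatic carbons and only dimethylamino or cyclopropylamino on the carbonyl carbon, so it remains open how chloro or methoxy would fare on the aromatic ring, or a longer-chain amine on the carbonyl carbon. Also open, going by these compounds, is what happens to the value of the shared core when hydrogen stands in place of every fluoro group on the ring.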